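A few compounds are considered here, and "the series" means these few. Any claim that something is new, unique, unknown or untested is made for them only; others in the source may bear on it.

In a functional assay on C3H/3T3 cells (Mus musculus) for cytotoxicity (a higher number here means that more compound is tolerated, a lower number that less compound is tolerated), compound 1 `Nc1ncnc2c1ncn2[C@H]1C=C[C@@H](CO)O1` gives > 50000 nM, which is a limit of the assay and not a number. Compound 2 `Nc1ncnc2c1ncn2[C@H]1C=C[C@@H](COP2(=O)OCc3ccccc3O2)O1` gives > 50000 nM, again only a limit. Compound 3 `Cc1cc(C)c2c(c1)COP(=O)(OC[C@@H]1C=C[C@H](n3cnc4c(N)ncnc43)O1)O2` gives > 50000 nM, likewise a limit. Among the measured compounds shown here, compound 3 therefore stands at the limit of > 50000 nM in this assay, at which 3 of the 3 values shown sit, and no compound shows a number in this assay. Compound 4 `Cc1cccc2c1OP(=O)(OC[C@@H]1C=C[C@H](n3cnc4c(N)ncnc43)O1)OC2` differs from compound 3 by hydrogen in place of methyl on an aromatic carbon. For the measured compounds named here, no measured step between two compounds is available to say how much such a change moves this assay. With compound 3 sitting at the limit of > 50000 nM in this assay, at which 3 of the 3 values shown sit, the step of a number no higher from compound 3 to compound 4 (the limit leaves the size open) is expected to be none beyond the scatter. Compound 4 is estimated at 50000 nM, within a range from 20000 nM to 50000 nM, most likely again reported only as a limit.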

Compound 4, minimum cytotoxic concentration in the C3H/3T3 assay: > 50000 nM
Compound 4: a limit, no number; the forecaster's own chance of this, stated with the estimate: 85%; the middle value sits exactly at the limit.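

Among the compounds shown here, in the C3H/3T3 assay compound 4 gives only a limit, as do compound 2 and compound 3, so no step from either of them to compound 4 can be read. In a physicochemical assay for lipophilicity (on this read-out lower numbers stand for lower lipophilicity and higher numbers for higher lipophilicity), compound 3 gives 0.95 and compound 4 gives 0.63. The compounds shown leave open at what concentration any of them becomes cytotoxic in the C3H/3T3 assay.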